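Cyclohexyl in Place of 4-Chlorobenzyl on the Amide Nitrogen

A few compounds are considered here, and "the series" means these few. Any claim that something is new, unique, unknown or untested is made for them only; others in the source may bear on it.

compound 1 `N[C@H]1CC[C@H](Nc2c(C(=O)NCc3ccc(Cl)cc3)nc(Br)c3cccnc23)CC1`: 2000 nM
compound 2 `Nc1ccc(Nc2c(C(=O)NCc3ccc(F)cc3)nc(Br)c3cccnc23)cc1`: 4000 nM

In a functional assay on SK-BR-3 cells (Homo sapiens) for cytotoxicity, read by MTT assay, with a stated time of 72 h (a lower number here means a stronger inhibitor, a higher number a weaker inhibitor), compound 1 gives the lowest of the two numbers, 2000 nM, while compound 2 gives 4000 nM; the gap between them lies within the usual scatter, so neither stands apart from the other. Compound 3 `N[C@H]1CC[C@H](Nc2c(C(=O)NC3CCCCC3)nc(Br)c3cccnc23)CC1` differs from compound 1 by cyclohexyl in place of 4-chlorobenzyl on an amide-type nitrogen. For the measured compounds named here, no measured pair shows this change, so its size is unknown. The step is estimated as a 1.8-fold higher number from compound 1 to compound 3 (0.24 log units; within the scatter), small and toward a higher number if anything. Compound 3 is therefore expected to give about 3500 nM, between 1200 nM and 10000 nM.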

Compound 3, half-maximal inhibitory concentration: 4200 nM
Beside the measured number, compound 3's estimate is 1.2-fold (0.08 log units) below it; measured number inside the range.
By their numbers in this assay, from the lowest: compounds 1, 2 and 3 (each within the scatter of the next, the first and the last beyond it).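

In this assay the exchange of 4-chlorobenzyl for cyclohexyl on the amide-type nitrogen gives a 2.1-fold higher number from compound 1 to compound 3 (0.32 log units; beyond the scatter) as a modest step beyond the scatter. For the compounds shown here, this is the first reading at this position, and it shows that the aromatic ring and its chlorine can both be lost at only that modest cost. No evidence here bears on what lies behind the step.

The change alters ring type, chlorine and ring attachment together, and the compounds shown do not separate these. From the compounds shown here alone, how a plain benzyl, a cyclohexylmethyl or a longer chain such as 2-phenylethyl on that nitrogen would read remains open.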